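This account rests on a few compounds, and the source may have more. Where it says the series, first, only, none or still open, it means among the compounds named here.

Compound 1 `Cc1cc(NC(=O)Nc2ccc(C(=O)O)cc2)c2ccccc2n1` is the anchor for the series in an ADME assay on HepG2 cells (Homo sapiens) for cytotoxicity, with a stated time of 72 h; a higher number here means that more compound is needed for the effect, a lower number that less compound is needed. In this assay compound 1 gives > 25000 nM, which is a limit of the assay and not a number. Compound 3 `Cc1cc(NC(=O)Nc2ccc(C(=O)O)c(O)c2)c2ccccc2n1` likewise gives > 25000 nM, again a limit. Compound 2 `COC(=O)c1cccc(NC(=O)Nc2cc(C)nc3ccccc23)c1` gives 23000 nM. The step that the two limits leave unreadable from compound 1 to compound 3 cannot be read because of the limit of > 25000 nM in this assay, at which 2 of the 3 values shown sit. Compound 4 `CCc1ccc(NC(=O)Nc2cc(C)nc3ccccc23)cc1` differs from compound 1 by ethyl in place of carboxy on an aromatic carbon. Within the data shown here, no measured step bears on this change; the only step between measured compounds lies between two limits, and the single number known, for compound 2, sits near that limit. No step beyond the scatter is therefore expected. Compound 4 is estimated at 20000 nM, with a range from 8000 nM to 50000 nM. The expected step is an at least 1.2-fold lower number from compound 1 to compound 4 (0.09 log units; that floor lies within the scatter).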

Compound 4, half-maximal effective concentration: 17000 nM
Compound 4: the middle estimate sits 1.2-fold (0.07 log units) above what was measured, and the stated range covers the measured number.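

Ethyl in place of carboxy, para to a large group, gives in this assay an at least 1.4-fold lower number from compound 1 to compound 4 (0.16 log units; that floor lies within the scatter). Unlike the hydroxy change from compound 1 to compound 3, which cannot be read since both values are limits, this change has a lower bound, though that bound does not clear the scatter. The step has no upper bound, so its full size stays unknown: the limit of > 25000 nM in this assay, at which 2 of the 4 values shown sit.

Still open, from the compounds shown here alone, is whether an amine or a longer chain at this position would give a step beyond the scatter. A primary amide in place of carboxy is equally untested among the compounds shown.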